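A Second Chloro on the Benzyl Group

The source may report more compounds than this note shows. Statements on the series, on what has been measured and on what is new or still open speak of the compounds shown alone.

Among the measured compounds shown here, in a functional assay on DU-145 cells (Homo sapiens) for inhibition, read by trypan blue exclusion, with a stated time of 96 h (a lower number here means a stronger inhibitor of growth, a higher number a weaker inhibitor of growth), compound 1 (`O=C(O)c1ccc(C(=O)/C(=C\c2ccc(Br)c([N+](=O)[O-])c2)SCc2ccccc2Cl)cc1`) gives 1000 nM and stands level with its only measured comparison. That comparison, compound 2 (`O=C(/C(=C\c1ccccc1OCc1ccccc1)S(=O)(=O)c1ccc(F)cc1)c1ccc(Cl)cc1`), gives 1000 nM and differs from it in more than one place. No measured single change therefore guides the next step. Compound 3 (`O=C(O)c1ccc(C(=O)/C(=C\c2ccc(Br)c([N+](=O)[O-])c2)SCc2ccc(Cl)cc2Cl)cc1`) differs from compound 1 by chloro in place of hydrogen on an aromatic carbon as chloro replaces hydrogen on an aromatic carbon, turning 2-chlorobenzyl into 2,4-dichlorobenzyl. The estimated step in this assay is a 1.3-fold lower number from compound 1 to compound 3 (0.10 log units; within the scatter) and is expected to stay within the scatter. For compound 3 the expected value is 800 nM with an estimated range from 250 nM to 2500 nM as its bounds.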

Compound 3, concentration for 50% growth inhibition: 1000 nM
Beside the measured number, compound 3's estimate is 1.3-fold (0.10 log units) below it, and the stated range covers the measured number.
By their numbers in this assay, from the lowest: compounds 1, 2 and 3 (each within the scatter of the next).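

Chloro in place of hydrogen on an aromatic carbon, para to a large group, gives no change at the digits printed from compound 1 to compound 3 (within the scatter) in this assay. Among the compounds shown here, this is the first single change that can be read, and it shows that 2-chlorobenzyl and 2,4-dichlorobenzyl stand level in this assay. No measured evidence bears on this result. The compounds shown leave open whether an amine or a methoxy group at this position would also stand level. They also leave open how the benzyl group reads with no chloro on it at all.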